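Aryl swap on the amide: clearance outlook for compound 3

The source may hold more compounds than are shown below. What is called first, only, known or untested is meant among the compounds shown, and "the series" means these compounds.

Compound 2 `CCCS(=O)(=O)N1CCC(CNC(=O)c2c(F)ccc(Cl)c2F)(C(=O)N2CCOCC2)CC1` gives 18 mL/min/kg in an in vivo ADME assay on the whole organism for pharmacokinetics, with Rattus norvegicus as the target (a lower number here means slower removal, a higher number faster removal of the compound), and stands level with compound 1 `CCCS(=O)(=O)N1CCC(CNC(=O)c2c(F)cccc2F)(C(=O)N2CCOCC2)CC1` at 18 mL/min/kg; the step of no change at the digits printed from compound 1 to compound 2 (within the scatter) stays within the scatter. Compound 3 `CCCS(=O)(=O)N1CCC(CNC(=O)c2ccc(F)cc2C(F)(F)F)(C(=O)N2CCOCC2)CC1` differs from compound 2 by 4-fluoro-2-(trifluoromethyl)phenyl in place of 3-chloro-2,6-difluorophenyl on a carbonyl carbon. Within the data shown here, only the one measured step bears on this change, and it concerned a smaller alteration of the same aromatic ring, so it offers limited guidance. For compound 3 no step beyond the scatter is expected, no change at the digits printed from compound 2 to compound 3 (within the scatter). The estimate for compound 3 in this assay is 18 mL/min/kg, with a range from 9 mL/min/kg to 36 mL/min/kg.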

Compound 3, clearance: 18 mL/min/kg
Beside the measured number, compound 3's estimate shows no gap at the digits printed; the measured number falls inside the stated range.
By their numbers in this assay, from the lowest: compounds 1, 2 and 3 (each within the scatter of the next).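

In this assay, exchanging the whole substituted aryl group on a carbonyl carbon, not just adding one chloro, gives no change at the digits printed from compound 2 to compound 3 (within the scatter). Measured against the 2,6-difluorophenyl group, the same 4-fluoro-2-(trifluoromethyl)phenyl group gives no change at the digits printed from compound 1 to compound 3 (within the scatter), so all three aryl groups shown at this place sit within the scatter. No measurement on hand accounts for this flat result.

All three groups are halogen-bearing phenyl rings with no hydrogen-bond donors or acceptors. From the compounds shown here alone, whether an aryl group carrying an amine or a carboxylic acid would hold this assay on the shared core remains open.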